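Replacing the 1H-indol-3-yl group on the double-bonded chain

The compounds below may be only part of what the source reports. "The series", "measured", "known", "first", "only" and "open" are said of these compounds alone.

Going by the values given here, in a functional assay on HCT-116 cells (Homo sapiens) for inhibition, read by MTT assay, with a stated time of 72 h (a lower number here means a stronger inhibitor, a higher number a weaker inhibitor), compound 1 (`Nc1ccccc1NC(=O)c1ccc(CNC(=O)/C=C/c2c[nH]c3ccccc23)cc1`) gives 1220 nM and so holds the lower of the two numbers known so far. Compound 2 (`Nc1ccc(F)cc1NC(=O)c1ccc(CNC(=O)/C=C/c2cnc3cccnn23)cc1`) gives 4290 nM and that number is higher by a margin beyond the usual scatter. Compound 3 (`Cc1nc2ccccn2c1/C=C/C(=O)NCc1ccc(C(=O)Nc2ccccc2N)cc1`) has not yet been measured. It departs from compound 1 in one place (a group of 10 heavy atoms (8 carbon, 2 nitrogen; one five-membered aromatic ring with 2 hetero atoms, one six-membered aromatic ring with 1 hetero atom) in place of a group of 9 heavy atoms (8 carbon, 1 nitrogen; one five-membered aromatic ring with 1 hetero atom, one six-membered aromatic ring of carbon only), on a double-bonded chain carbon bound to a double-bonded chain carbon). Among the compounds with values here, no measured pair shows this change on its own. Compound 2 also carries no 1H-indol-3-yl group and gives 4290 nM but it differs from compound 1 elsewhere too, so it offers only a loose guide. A moderate rise in the number is therefore expected in this assay, and the estimated step (a 2.3-fold higher number from compound 1 to compound 3 (0.36 log units; beyond the scatter)) lies only slightly beyond the scatter. For compound 3 the estimated value is 2800 nM within an expected range (1000 nM to 6500 nM).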

Compound 3, half-maximal inhibitory concentration: 1430 nM
Estimate against measurement, compound 3: 2.0-fold (0.29 log units) above, and the stated range covers the measured number.
By their numbers in this assay, from the lowest: compounds 1 and 3 (each within the scatter of the next); then compound 2.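

In this assay, the step at this position is small: a 1.2-fold higher number from compound 1 to compound 3 (0.07 log units; within the scatter). On a double-bonded chain carbon bound to a double-bonded chain carbon, this pair therefore shows that the 1H-indol-3-yl group, with its hydrogen-bond donor, can give way to a group with 0 hydrogen-bond donors and 2 hydrogen-bond acceptors without a measurable difference in this assay. Nothing available explains this result.

Compound 2 differs from compound 1 in more than one place, so its number cannot be assigned to any single difference. The compounds shown also leave open how a plain phenyl group, a smaller group such as methyl, or a carboxylic acid would behave on the same chain carbon.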